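Swapping a Benzyl for a Butyl on a Sigma Ligand

The source may report more compounds than this note shows. Statements on the series, on what has been measured and on what is new or still open speak of the compounds shown alone.

Compound 1 `COc1cc2c(cc1C(C)N[C@@H](C)c1ccccc1)C=CC(C)(C)O2`: 805 nM
Compound 2 `COc1cc2c(cc1C(C)NCc1ccccc1)CCC(C)(C)O2`: 119 nM

Of the two compounds measured in an assay on cell membranes for displacement of a labelled ligand from Sigma non-opioid intracellular receptor 1 (Cavia porcellus), read by scintillation counting (a higher number here means a weaker inhibitor, a lower number a stronger inhibitor), compound 2 gives the lower number, 119 nM, and compound 1 gives 805 nM, a gap beyond the scatter. Compound 3 `CCCCNC(C)c1cc2c(cc1OC)OC(C)(C)CC2` has not been measured. It differs from compound 2 by propyl in place of phenyl on a saturated chain carbon bound to an amine nitrogen. Among the measured compounds shown here, no measured pair shows this kind of change, so the direction is uncertain; a modest loss is expected, giving a step of a 2.5-fold higher number from compound 2 to compound 3 (0.40 log units; beyond the scatter) in this assay. For compound 3 the estimated value is 300 nM, expected between 80 nM and 1200 nM.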

Compound 3, inhibition constant: 43 nM
For compound 3 the middle estimate is 7.0-fold (0.84 log units) above the measured one; the whole stated range lies above it.
By their numbers in this assay, from the lowest: compound 3; then compound 2; then compound 1.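

In this assay, an aromatic ring is not required at this position: putting propyl in place of phenyl on a saturated chain carbon bound to an amine nitrogen gives a 2.8-fold lower number from compound 2 to compound 3 (0.44 log units; beyond the scatter). The propyl group has fewer heavy atoms than phenyl and no ring. Compound 1 and compound 2 could not show this, since both carry a phenyl ring there. Nothing measured here explains the gain. Still open, from the compounds shown here alone, is how a longer chain, such as hexyl, or a saturated ring, such as cyclohexyl, would compare with butyl on the amine nitrogen.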